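The compounds below may be only part of what the source reports. "The series", "measured", "known", "first", "only" and "open" are said of these compounds alone.

In an assay on MCF7 cells for inhibition of Serine-protein kinase ATM (Homo sapiens), read by immunofluorescence, with a stated time of 1 h (on this read-out higher numbers stand for weaker inhibition and lower numbers for stronger inhibition), compound 1 `COc1cc2ncnc(-n3nc(-c4ccccn4)nc3N)c2cc1OCCCN1CC(C)OC(C)C1` gives 1600 nM, the lower of the two numbers recorded, and compound 2 `COc1cc2ncnc(-n3nc(-c4ccccn4)nc3N)c2cc1OCCCNC(=O)CN1C[C@@H](C)O[C@@H](C)C1` stands close to it with 1700 nM. Going by the values given here, the one step measured between these two, a 1.1-fold higher number from compound 1 to compound 2 (0.03 log units; within the scatter), lies within the scatter. Compound 3 `COc1cc2ncnc(-n3nc(-c4ccccn4)nc3N)c2cc1OCCNC(=O)OC(C)(C)C` is not yet measured in this assay. Its difference from compound 1 is (tert-butoxycarbonyl)amino in place of (2,6-dimethylmorpholin-4-yl)methyl on a saturated chain carbon, two bonds along the chain from an oxygen on an aromatic ring. Among the compounds with values here, the measured step bearing on this change is the one from compound 1 to compound 2, in which the chain end was recast from a dimethylmorpholine into an amide bearing the same ring and the number hardly moved. Compound 3 goes further: the ring leaves altogether and a carbamate with a tert-butyl group enters on a chain one carbon shorter. Because a 1.1-fold higher number from compound 1 to compound 2 (0.03 log units; within the scatter) was flat, the chain end appears tolerant, yet the loss of the ring is a larger change than that step covered, so a modest rise in the number, or none beyond the scatter, is expected for compound 3, the step being estimated as a 1.6-fold higher number from compound 1 to compound 3 (0.19 log units; within the scatter). Compound 3 is therefore expected to give about 2500 nM, within a range of 800 nM to 8000 nM.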

Compound 3, half-maximal inhibitory concentration: 800 nM
Compound 3: middle estimate off by 3.1-fold (0.49 log units), on the high side; the measured number falls inside the stated range.
By their numbers in this assay, from the lowest: compounds 3, 1 and 2 (each within the scatter of the next, the first and the last beyond it).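

In this assay, a 2.0-fold lower number from compound 1 to compound 3 (0.30 log units; within the scatter), so the 3-(2,6-dimethylmorpholin-4-yl)propoxy end can give way to 2-((tert-butoxycarbonyl)amino)ethoxy with no change beyond the scatter. Until now, the six-membered ring had been present in every measured compound, and this result shows that a compound with no ring in this part of the molecule, and with a hydrogen-bond donor that compound 1 lacks, stays within the scatter of compound 1, although the values of compound 3 and compound 2 lie beyond the scatter of each other. No evidence is available to explain this tolerance of a different chain end.

The change alters the chain length and the end group together, so their separate contributions, which could offset each other, remain unresolved. Going by these compounds, it also stays open how the same (tert-butoxycarbonyl)amino group would read on the longer propoxy chain, and how a free primary amine or a carboxylic acid would read at the end of the ethoxy chain.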